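This account rests on a few compounds, and the source may have more. Where it says the series, first, only, none or still open, it means among the compounds named here.

Compound 1, `CCOC(=O)c1c[nH]nc1N/C=C1\C(=O)NN=C1c1ccccc1`, was tested in a functional assay on MDA-MB-453 cells (Homo sapiens) for antiproliferative activity, read by MTT assay, with a stated time of 72 h (a lower number here means a stronger inhibitor, a higher number a weaker inhibitor), where compound 1 gives 74600 nM. Its number sits among three close ones: compound 2, `O=C1NN=C(c2ccccc2)/C1=C/Nc1cc[nH]n1`, gives 74900 nM, and compound 3, `CSCC[C@H](N/C=C1\C(=O)NN=C1c1ccccc1)C(=O)O`, gives 42200 nM, and neither of these two lies beyond the usual scatter of the number of compound 1. Among the compounds with values here, the one single-point step among the measured compounds, a 1.0-fold higher number from compound 1 to compound 2 (0.00 log units; within the scatter), concerns the ethoxycarbonyl group on the aromatic carbon and leaves the number essentially where it was. Within the data shown here, for compound 3 no step to compound 1 is set out; its number and that of compound 1 simply lie within the scatter of each other.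

Compound 4, `CCOC(=O)c1c[nH]nc1N/C=C1\C(=O)N(c2ccccc2)N=C1c1ccccc1`, differs from compound 1 in one place: phenyl in place of hydrogen on an amide-type nitrogen in a ring. Among the measured compounds shown here, no measured step touches the amide-type nitrogen in the ring, so the available data give no direct guide to the size or direction of this change. With the three numbers all lying close together, the author expects compound 4 to stay in the same weak region, with an estimated step of a 1.1-fold lower number from compound 1 to compound 4 (0.06 log units; within the scatter) that does not go beyond the scatter. The estimate for compound 4 in this assay is 65000 nM, expected to fall between 20000 nM and 200000 nM.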

Compound 4, half-maximal inhibitory concentration: 19400 nM
Compound 4: middle estimate off by 3.4-fold (0.53 log units), on the high side; measured number outside the range, below it.
By their numbers in this assay, from the lowest: compound 4; then compounds 3, 1 and 2 (each within the scatter of the next).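

Phenyl in place of hydrogen on the amide-type nitrogen in the ring produces the only single-place step in this assay that goes beyond the scatter, with a 3.8-fold lower number from compound 1 to compound 4 (0.58 log units; beyond the scatter) and a modest size. The one earlier step of this kind, a 1.0-fold higher number from compound 1 to compound 2 (0.00 log units; within the scatter), concerned the ethoxycarbonyl group on the aromatic carbon and stayed within the scatter, so this nitrogen is the first place shown where a single change moves the number, and the move is towards a stronger inhibitor, with compound 4 at 19400 nM in the same assay. No evidence at hand bears on why the added phenyl ring has this effect.

The compounds shown leave open whether the step calls for an aromatic ring on this nitrogen or whether a smaller methyl group, a benzyl group or a chlorophenyl group would give a similar number. They also leave open whether phenyl at the same nitrogen would give a step of similar size and direction on the cores of compound 2 and compound 3, which both carry hydrogen there.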